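Swapping sulfur for selenium on two inactive core pairs

The source may report more compounds than this note shows. Statements on the series, on what has been measured and on what is new or still open speak of the compounds shown alone.

Measured so far, each in a functional assay on HT-29 cells (Homo sapiens) for cytotoxicity, read by MTT assay, with a stated time of 72 h; on this read-out higher numbers stand for weaker inhibition of growth and lower numbers for stronger inhibition of growth:

Compound 1, `CS/C(=N\C(=O)c1ccno1)NC(=O)c1ccno1`, reaches only the limit of the assay, > 100000 nM.
Compound 2, `C[Se]/C(=N\C(=O)c1ccno1)NC(=O)c1ccno1`, likewise reaches only the limit, > 100000 nM.
Compound 3, `CS/C(=N\C(=O)c1cc(-c2ccccc2)nc2ccccc12)NC(=O)c1cc(-c2ccccc2)nc2ccccc12`, also reaches only the limit, > 100000 nM.

Compound 1 and compound 2 share one core and differ in a single spot: a group of 2 heavy atoms (1 carbon, 1 selenium; no ring) in place of a group of 2 heavy atoms (1 carbon, 1 sulfur; no ring), on a carbon with a double bond to nitrogen. The step this makes is a step that the two limits leave unreadable from compound 1 to compound 2, so its size cannot be read, because of the limit of > 100000 nM in this assay, at which 3 of the 3 values shown sit.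

Compound 3 carries a different core; the difference between the two cores is not broken down here. Compound 4, `C[Se]/C(=N\C(=O)c1cc(-c2ccccc2)nc2ccccc12)NC(=O)c1cc(-c2ccccc2)nc2ccccc12`, has not yet been measured in this assay. It relates to compound 3 exactly as compound 2 relates to compound 1: a group of 2 heavy atoms (1 carbon, 1 selenium; no ring) in place of a group of 2 heavy atoms (1 carbon, 1 sulfur; no ring), on a carbon with a double bond to nitrogen. Since the place lines are the same word for word, this is the same change made a second time.

Within the data shown here, because of the limit of > 100000 nM in this assay, at which 3 of the 3 values shown sit, there is no measured step to carry over, only the observation that neither core produced a readable number with either group. The expected step from compound 3 to compound 4 in this assay is therefore a number no higher from compound 3 to compound 4 (the limit leaves the size open), meaning roughly no change. Compound 4 is estimated at 100000 nM, with a range from 30000 nM to 300000 nM, and most likely the assay will again report only a limit.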

Compound 4, concentration for total growth inhibition: 90700 nM
Beside the measured number, compound 4's estimate is 1.1-fold (0.04 log units) above it; the range from low to high includes it.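

In this assay, putting the group of carbon and selenium in place of methylsulfanyl on the core of compound 3 gives an at least 1.1-fold lower number from compound 3 to compound 4 (0.04 log units; that floor lies within the scatter). That figure is only a floor set by a limit, not the true size of the step, so the result shows that this core with the selenium group yields a readable number but does not establish that the change itself has any effect. The same change on the core of compound 1 leaves a step that cannot be read, so there are no two sizes to set side by side, and nothing here shows whether the change carries over from one core to the other, because nearly all the values are limits: the limit of > 100000 nM in this assay, at which 3 of the 4 values shown sit.

The compounds shown carry only methylsulfanyl or its selenium counterpart on the carbon with a double bond to nitrogen, so it remains open what an amine or a longer chain would do in that place. Also open, from the compounds shown here alone, are the real size of the step on the core of compound 3 and how either group would behave on a core bearing a carboxylic acid.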